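Series notes: aryl swap from compound 2 to compound 3

The source may hold more compounds than are shown below. What is called first, only, known or untested is meant among the compounds shown, and "the series" means these compounds.

Among the compounds with values here, compound 2 `CC/C(=C(/c1ccc(/C=C/C(=O)O)cc1)c1cc2ccccc2[nH]1)c1cccc(Cl)c1Cl` gives 898 nM in a functional assay on MCF7 cells (Homo sapiens) for inhibition (on this read-out higher numbers stand for weaker inhibition and lower numbers for stronger inhibition), and stands highest of the two numbers measured so far. Within the data shown here, compound 1 `CC/C(=C(/c1ccc(/C=C/C(=O)O)cc1)c1cc2ccccc2[nH]1)c1ccc(C#N)cc1` gives 278 nM in this assay and is its nearest neighbour; the step of a 3.2-fold higher number from compound 1 to compound 2 (0.51 log units; beyond the scatter) is the only measured change at this position, and it runs toward weaker inhibition when the nitrile-bearing ring is exchanged for the dichlorinated one. Compound 3 `CC/C(=C(/c1ccc(/C=C/C(=O)O)cc1)c1cc2ccccc2[nH]1)c1cccc(F)c1C#N` differs from compound 2 by 2-cyano-3-fluorophenyl in place of 2,3-dichlorophenyl on a double-bonded chain carbon bound to a double-bonded chain carbon and a saturated chain carbon. This change brings a nitrile back onto the ring, though at a different position than in compound 1, together with a fluorine, so the measured step bears only partly on it. A move back toward the number of compound 1 is expected, a 1.8-fold lower number from compound 2 to compound 3 (0.25 log units; within the scatter), but with wide uncertainty. Compound 3 is therefore estimated at 500 nM, within a range of 150 nM to 1600 nM.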

Compound 3, half-maximal inhibitory concentration: 40 nM
Compound 3: the middle estimate sits 13-fold (1.10 log units) above what was measured; measured number below the stated range.
By their numbers in this assay, from the lowest: compound 3; then compound 1; then compound 2.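

In this assay this position proves more sensitive to the aryl group than the earlier pair indicated, with a 22-fold lower number from compound 2 to compound 3 (1.35 log units; beyond the scatter) as a large step on a single exchange. The 2-cyano-3-fluorophenyl group also outdoes the 4-cyanophenyl group, with a 7.0-fold lower number from compound 1 to compound 3 (0.84 log units; beyond the scatter) lying beyond the scatter, so the presence of a nitrile on the ring does not alone fix the number, since compound 1 and compound 3 both carry one. No available evidence accounts for either step.

The compounds shown leave open whether the gain in compound 3 belongs to the nitrile, to the fluorine or to the two together, as both differ from compound 2 in one exchange. Within the data shown here, also open is how a phenyl ring carrying only one of these groups would read, or one carrying a methoxy group or an amine instead.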